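A few compounds are considered here, and "the series" means these few. Any claim that something is new, unique, unknown or untested is made for them only; others in the source may bear on it.

Within the data shown here, in a functional assay on DU-145 cells (Homo sapiens) for inhibition, read by trypan blue exclusion, with a stated time of 96 h (a lower number here means a stronger inhibitor of growth, a higher number a weaker inhibitor of growth), compound 3 `Cc1cc(C)cc(/C=C(\C(=O)c2ccc(Cl)cc2)S(=O)(=O)c2ccc(Br)cc2)c1` gives 10000 nM, the middle of the three numbers so far: compound 2 `Cc1ccc(C)c(/C=C(\C(=O)c2ccc(Cl)cc2)S(=O)(=O)c2ccc(Br)cc2)c1` gives 1000 nM and compound 1 `Cc1ccc(CS/C(=C/c2c(O)cc(O)cc2O)C(=O)c2ccc(Cl)cc2)cc1` gives 50000 nM. Compound 4 `O=C(/C(=C\c1c(O)cc(O)cc1O)S(=O)(=O)c1ccc(Br)cc1)c1ccc(Cl)cc1` differs from compound 3 in one group: 2,4,6-trihydroxyphenyl in place of 3,5-dimethylphenyl on a double-bonded chain carbon bound to a double-bonded chain carbon. Among the measured compounds shown here, the one measured step at this place is a 10-fold higher number from compound 2 to compound 3 (1.00 log units; beyond the scatter), which shows that a change here can matter, but it involves no hydroxyl groups and gives no direction for this swap. Compound 1 also carries 2,4,6-trihydroxyphenyl, but it differs elsewhere, so it is only a loose guide. The expected step is no change at the digits printed from compound 3 to compound 4 (within the scatter), with no direction favoured. For compound 4 the estimated value is 10000 nM, within an expected range of 2000 nM to 50000 nM.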

Compound 4, concentration for 50% growth inhibition: > 100000 nM
Compound 4: no number, only a limit; the forecaster's own chance of this, stated with the estimate: 10%; middle value at least 10-fold (1.00 log units) from the limit.
By their numbers in this assay, from the lowest: compound 2; then compound 3; then compound 1. At a limit, above all of these: compound 4.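

Compound 4 gives only a limit, not a number: the limit of > 100000 nM in this assay, at which 1 of the 4 values shown sits. Placing 2,4,6-trihydroxyphenyl at this position clearly weakens growth inhibition, giving an at least 10-fold higher number from compound 3 to compound 4 (1.00 log units; beyond the scatter) and an at least 100-fold higher number from compound 2 to compound 4 (2.00 log units; beyond the scatter), so this swap moves the number further than the shift between dimethylphenyl patterns did. The step of an at least 2.0-fold higher number from compound 1 to compound 4 (0.30 log units; that floor lies within the scatter) cannot be read as a real change.

As far as these compounds go, how far compound 4 lies past its limit stays unknown, so the true size of these steps does too. From the compounds shown here alone, whether a single hydroxyl, a methoxy or an amine at this place would also weaken growth inhibition remains open.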